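The source may hold more compounds than are shown below. What is called first, only, known or untested is meant among the compounds shown, and "the series" means these compounds.

Measured so far in a functional assay on B16 cells (Mus musculus) for antiproliferative activity, read by MTT assay, with a stated time of 24 h; a lower number here means a stronger inhibitor, a higher number a weaker inhibitor:
compound 1, `COc1cc(OC)c(-c2coc3cc(OCC(=O)c4cccc(C(F)(F)F)c4)ccc3c2=O)cc1OC`, gives only a limit of the assay, > 10000 nM.
compound 2, `COc1cc(OC)c(-c2coc3cc(OCc4ccccc4C)ccc3c2=O)cc1OC`, gives 2150 nM.
compound 3, `COc1cc(OC)c(-c2coc3cc(OCc4cccc(Cl)c4)ccc3c2=O)cc1OC`, gives 2280 nM.

Compound 2 gives the lower of the two numbers, but compound 3 sits within the usual scatter of it, so the two cannot be told apart. The step of an at least 4.6-fold lower number from compound 1 to compound 2 (0.66 log units; beyond the scatter) and the step of an at least 4.3-fold lower number from compound 1 to compound 3 (0.64 log units; beyond the scatter) both start from a limit and are counted only as at-least values; see (the limit of > 10000 nM in this assay, at which 1 of the 3 values shown sits).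

The next compound, compound 4, is `COc1cc(OC)c(-c2coc3cc(OCc4ccc(C(F)(F)F)cc4)ccc3c2=O)cc1OC`. It differs from compound 2 by 4-(trifluoromethyl)phenyl in place of 2-methylphenyl on a saturated chain carbon bound to an oxygen on an aromatic ring.

Which steps bear on this? The step of a 1.1-fold higher number from compound 2 to compound 3 (0.03 log units; within the scatter) shows that swapping one substituent on the phenyl for another left the number essentially unchanged. The step of an at least 4.6-fold lower number from compound 1 to compound 2 (0.66 log units; beyond the scatter) concerns a different kind of group and says little here. The expectation for compound 4 is therefore a step of about a 1.2-fold higher number from compound 2 to compound 4 (0.08 log units; within the scatter), which is none beyond the scatter. Compound 4 is estimated at 2600 nM, within 1000 nM to 7000 nM.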

Compound 4, half-maximal inhibitory concentration: 5400 nM
Compound 4: the middle estimate sits 2.1-fold (0.32 log units) below what was measured; measured number inside the range.
By their numbers in this assay, from the lowest: compounds 2 and 3 (each within the scatter of the next); then compound 4. At a limit, above all of these: compound 1.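

In this assay, the group on this phenyl ring now makes a visible difference: the 4-(trifluoromethyl)phenyl group gives a 2.5-fold higher number from compound 2 to compound 4 (0.40 log units; beyond the scatter) and a 2.4-fold higher number from compound 3 to compound 4 (0.37 log units; beyond the scatter), both modest. The earlier swap of 2-methylphenyl for 3-chlorophenyl had left compound 2 and compound 3 within the scatter of each other. Each new step changes both the substituent and its numbered place on the ring, so these compounds cannot separate the two effects. The step of an at least 1.8-fold lower number from compound 1 to compound 4 (0.26 log units; that floor lies within the scatter) starts from a limit and is counted only as an at-least value: the limit of > 10000 nM in this assay, at which 1 of the 4 values shown sits.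

Still open, as far as these compounds go, is how 2-(trifluoromethyl)phenyl or 3-(trifluoromethyl)phenyl would compare on the same carbon. Also open, from the compounds shown here alone, is what an amine or a carboxylic acid on the ring, or a longer chain before it, would do to the number.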